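A few compounds are considered here, and "the series" means these few. Any claim that something is new, unique, unknown or untested is made for them only; others in the source may bear on it.

Compound 1 `Cc1cc(C)cc(NN=C2CCC(C)n3c2ncc(C(=O)O)c3=O)c1` was examined in a functional assay on the whole organism with Rattus norvegicus as the target; a lower number here means that less compound is needed, a higher number that more compound is needed for the effect. In this assay compound 1 gives > 320 umol/kg, which is a limit of the assay and not a number. Compound 2 `CC1CCC(=NNc2ccc3ccccc3c2)c2ncc(C(=O)O)c(=O)n21` was examined in the same way. In this assay compound 2 gives > 100 umol/kg, again a limit of the assay rather than a number. Compound 1 thus stands at the limit of > 320 umol/kg in this assay, at which 1 of the 2 values shown sits, while the other value sits at the limit of > 100 umol/kg in this assay, at which 1 of the 2 values shown sits; neither compound has a numerical dose, so no order between them can be stated.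

Compound 3 `CNN=C1CCC(C)n2c1ncc(C(=O)O)c2=O` differs from compound 1 in a single place (methyl in place of 3,5-dimethylphenyl on an amine nitrogen). For the measured compounds named here, no measured pair shows the effect of such a change, so no size can be read from the record. Compound 3 is expected to give 320 umol/kg, with a range from 100 umol/kg to 1000 umol/kg. The step this estimate means, a number no higher from compound 1 to compound 3 (the limit leaves the size open), is expected to be none beyond the usual scatter, most likely ending again at a limit.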

Compound 3, dose for 50% inhibition: > 100 umol/kg
Compound 3 ended at the assay's limit; the forecaster's own chance of this, stated with the estimate: 75%; the middle value is on the limit's open side.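

Compound 3, like compound 1, ends at a limit of this assay, so the step between them cannot be read. The compounds shown leave open what dose any of them would need, and whether methyl or 3,5-dimethylphenyl on the amine nitrogen makes any difference.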